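Working Notes on a Dichloro Substitution Pair

The compounds below may be only part of what the source reports. "The series", "measured", "known", "first", "only" and "open" are said of these compounds alone.

All numbers below come from a functional assay on SF-539 cells (Homo sapiens) for cytotoxicity, read by sulforhodamine B assay, with a stated time of 48 h; a higher number here means a weaker inhibitor of growth, a lower number a stronger inhibitor of growth.

compound 1, `ClCc1cccc(Cn2cnc3ncnc(Cl)c32)c1`: 36300 nM
compound 2, `ClCc1ccccc1Cn1cnc2ncnc(Cl)c21`: 5010 nM
compound 3, `ClCc1cccc(Cn2cnc3nc(Cl)nc(Cl)c32)c1`: 460 nM

Compound 1 and compound 2 are built from the same atoms joined differently; the difference between the two cores is not broken down here. In this assay compound 2 sits well under compound 1, and compound 3 sits under both.

Within the data shown here, the single counted change in the set is chloro in place of hydrogen on an aromatic carbon. It carries a 79-fold lower number from compound 1 to compound 3 (1.90 log units; beyond the scatter), a large step by any standard of this assay.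

Compound 4, `ClCc1ccccc1Cn1cnc2nc(Cl)nc(Cl)c21`, is not yet measured. Among the measured compounds shown here, it is related to compound 2 by chloro in place of hydrogen on an aromatic carbon, which is the same kind of change as the one from compound 1 to compound 3, made on the other core. The two place descriptions read the same word for word, so nothing around the site of the change differs between the two pairs.

For the measured compounds named here, with only one measured instance, the expectation is that the change repeats with similar size, somewhat hedged because a 79-fold lower number from compound 1 to compound 3 (1.90 log units; beyond the scatter) is a single observation on a different core. For compound 4 the expected step is a 50-fold lower number from compound 2 to compound 4 (1.70 log units; beyond the scatter). Compound 4 is therefore estimated at 100 nM, with a likely range from 25 nM to 400 nM.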

Compound 4, concentration for total growth inhibition: 4260 nM
The estimate for compound 4 lay 43-fold (1.63 log units) below the measured number, outside the stated range (above it).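

In this assay, chloro in place of hydrogen on an aromatic carbon gives a 1.2-fold lower number from compound 2 to compound 4 (0.07 log units; within the scatter), so on the core of compound 2 the change leaves the number inside the scatter. The same change therefore does not carry over at one size from the core of compound 1 to the core of compound 2, even though the words describing the site are identical in both pairs: the same change on two cores in this assay, a 79-fold lower number (1.90 log units; beyond the scatter) from compound 1 to compound 3 and a 1.2-fold lower number (0.07 log units; within the scatter) from compound 2 to compound 4, 67-fold (1.83 log units) apart, beyond the scatter of two such steps

This shows that, in this series, the large step on the core of compound 1 cannot be read as a fixed contribution of the chloro group and that its size depends on the core that carries it, but it does not show which feature of the two cores is responsible, and with a single pair on each core it cannot say which of the two steps is the more typical.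

On these data alone, it remains open whether an amine or a methoxy group on the same aromatic carbon, between two ring nitrogen atoms, would also give steps that differ between the two cores. A further open question is whether the gap between the two steps would persist in cell lines other than the one shown here.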